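Aryl Hydrazone Swap on a Quinoline Urea: Pyridyl Variant

The source may report more compounds than this note shows. Statements on the series, on what has been measured and on what is new or still open speak of the compounds shown alone.

Measured compounds:
compound 1 `COc1cc2c(Oc3ccc(NC(=O)N/N=C/c4ccc([N+](=O)[O-])cc4)cc3F)ccnc2cc1OCCCN1CCCC1` in a functional assay on MKN-45 cells (Homo sapiens) for cytotoxicity, read by MTT assay, with a stated time of 72 h (a higher number here means a weaker inhibitor, a lower number a stronger inhibitor), compound 1 gives 470 nM
compound 2 `COc1cc2c(Oc3ccc(NC(=O)N/N=C/c4ccc(Cl)cc4Cl)cc3F)ccnc2cc1OCCCN1CCCCC1` in this assay compound 2 gives 460 nM
compound 3 `COc1ccc(/C=N/NC(=O)Nc2ccc(Oc3ccnc4cc(OCCCN5CCCCC5)c(OC)cc34)c(F)c2)c(OC)c1` in this assay compound 3 gives 1990 nM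

Compound 3 carries the highest number of the three; compound 1 sits a little closer to it than compound 2, and both of those gaps lie beyond the scatter. For the measured compounds named here, the only measured step that touches the group on the carbon double-bonded to nitrogen is a 4.3-fold higher number from compound 2 to compound 3 (0.64 log units; beyond the scatter), a modest rise when 2,4-dimethoxyphenyl replaces 2,4-dichlorophenyl.

Compound 4 `COc1cc2c(Oc3ccc(NC(=O)N/N=C/c4ccncc4)cc3F)ccnc2cc1OCCCN1CCCCC1` differs from compound 3 by pyridin-4-yl in place of 2,4-dimethoxyphenyl on a carbon with a double bond to nitrogen. Going by the values given here, no measured pair shows a pyridin-4-yl at this carbon, so the step from compound 2 to compound 3 is the only guide: it shows that the group at this position can move the number by a modest amount, and that compound 3 is the weakest of the three. The expectation is that compound 4 moves back toward the numbers of compounds 1 and 2, with an estimated step of a 2.2-fold lower number from compound 3 to compound 4 (0.34 log units; beyond the scatter), though a change within the scatter cannot be excluded. Compound 4 is therefore estimated at 900 nM, within a range of 350 nM to 2500 nM.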

Compound 4, half-maximal inhibitory concentration: 980 nM
The estimate for compound 4 lay 1.1-fold (0.04 log units) below the measured number, within the range that was stated.
By their numbers in this assay, from the lowest: compounds 2 and 1 (each within the scatter of the next); then compound 4; then compound 3.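

In this assay, pyridin-4-yl extends the groups read on this carbon beyond substituted phenyl rings, and compound 4 falls in the middle of the two phenyl compounds, with a 2.0-fold lower number from compound 3 to compound 4 (0.31 log units; beyond the scatter) on one side and a 2.1-fold higher number from compound 2 to compound 4 (0.33 log units; beyond the scatter) on the other. Both steps are modest but beyond the scatter, so this change moves the number in either direction depending on which phenyl group it replaces, and the position responds to more than the two substituted phenyl rings had shown. Replacing the 10 heavy atoms of 2,4-dimethoxyphenyl with the 6 of pyridin-4-yl lowers the number without reaching the value of compound 2, and nothing given here accounts for this order.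

The compounds shown do not separate the effect of the ring nitrogen from the loss of the substituents, a comparison that an unsubstituted phenyl on this carbon would address. They also leave open how pyridin-3-yl or pyridin-2-yl would compare, and whether an amine or a carboxylic acid on the pyridine ring would move the number further.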